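Dropping the Methyl from the Benzyl Group of Compound 1

The compounds below may be only part of what the source reports. "The series", "measured", "known", "first", "only" and "open" are said of these compounds alone.

Compound 1 `Cc1ccccc1COc1n[nH]c(=S)n1/N=C/c1c[nH]nc1-c1ccc(Cl)cc1` gives 44 ug/mL in a functional assay on HepG2 cells (Homo sapiens) for cytotoxicity, read by MTT assay, with a stated time of 24 h (on this read-out lower numbers stand for stronger inhibition and higher numbers for weaker inhibition), the lowest of the two numbers here. Compound 3 `Cc1ccccc1COc1n[nH]c(=S)n1/N=C/c1c[nH]nc1-c1ccc(F)cc1` gives 48 ug/mL in this assay, and a 1.1-fold higher number from compound 1 to compound 3 (0.04 log units; within the scatter). Compound 2 `CCc1n[nH]cc1/C=N/n1c(OCc2ccc(C)cc2)n[nH]c1=S` sits at the limit of > 100 ug/mL in this assay, at which 1 of the 3 values shown sits, so its value > 100 ug/mL is a limit and not a number.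

Compound 4 `S=c1[nH]nc(OCc2ccccc2)n1/N=C/c1c[nH]nc1-c1ccc(Cl)cc1` differs from compound 1 by hydrogen in place of methyl on an aromatic carbon. Going by the values given here, no measured step involves this kind of change; the only measured step, from compound 1 to compound 3, concerns a different position and stays within the scatter. With nothing pointing either way, a step of a 1.1-fold higher number from compound 1 to compound 4 (0.06 log units; within the scatter) is expected, none beyond the scatter. Compound 4 is therefore estimated at 50 ug/mL, with a range from 25 ug/mL to 100 ug/mL.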

Compound 4, half-maximal inhibitory concentration: 18 ug/mL
Compound 4: the middle estimate sits 2.8-fold (0.44 log units) above what was measured; the measured number lies below the stated range.
By their numbers in this assay, from the lowest: compound 4; then compounds 1 and 3 (each within the scatter of the next). At a limit, above all of these: compound 2.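

In this assay, hydrogen in place of methyl on this aromatic carbon gives a 2.4-fold lower number from compound 1 to compound 4 (0.39 log units; beyond the scatter), a modest step but one that goes beyond the scatter. So the methyl of the 2-methylbenzyl group is not needed for this read-out, and the plain benzyl compound gives the lower number. Nothing measured here tells why the number moves with this change. Still open, on these data alone, is how an amine or a methoxy group on this same carbon would read, and whether dropping the methyl gives a similar step in compound 3, which carries fluoro in place of chloro.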